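The compounds below may be only part of what the source reports. "The series", "measured", "known", "first", "only" and "open" are said of these compounds alone.

Measured so far in a functional assay on HT-29 cells (Homo sapiens) for antiproliferative activity; a higher number here means a weaker inhibitor, a lower number a stronger inhibitor:
- compound 1 `COc1ccc(S(=O)(=O)N2CCc3cccc(Nc4ccccc4)c32)cc1` gives 343 nM
- compound 2 `COc1ccc(S(=O)(=O)N2CCc3cccc(Nc4ccc([N+](=O)[O-])cc4)c32)cc1` gives 191 nM

With only these two values available, compound 2 stands within the scatter of compound 1 and no order can be drawn between them. The next compound is compound 3 `COc1ccc(S(=O)(=O)N2CCc3cccc(Nc4ccc(C#N)cc4)c32)cc1`, which differs from compound 2 as follows: cyano in place of nitro on an aromatic carbon. In words, this is cyano in place of nitro on an aromatic carbon. Within the data shown here, the one measured step that bears on this change is a 1.8-fold lower number from compound 1 to compound 2 (0.25 log units; within the scatter), nitro in place of hydrogen on an aromatic carbon, and it is small. Among the measured compounds shown here, with only that step to go on, no shift beyond the scatter is expected in this assay, in either direction. The expected change is a 1.2-fold higher number from compound 2 to compound 3 (0.08 log units; within the scatter). Compound 3 is estimated at 230 nM, with an expected range of 100 nM to 520 nM.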

Compound 3, half-maximal inhibitory concentration: 149 nM
Compound 3: the middle estimate sits 1.5-fold (0.19 log units) above what was measured; low and high end bracket the measured number.
By their numbers in this assay, from the lowest: compounds 3, 2 and 1 (each within the scatter of the next, the first and the last beyond it).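

In this assay, cyano in place of nitro on this aromatic carbon, para to a large group, gives a 1.3-fold lower number from compound 2 to compound 3 (0.11 log units; within the scatter) and so leaves the (4-cyanophenyl)amino and (4-nitrophenyl)amino compounds without an order. Against the unsubstituted ring, the cyano group gives a 2.3-fold lower number from compound 1 to compound 3 (0.36 log units; beyond the scatter) and is the first step in the series to pass the scatter, though only modestly, so a substituent at this place can lower the number measurably. Nothing available accounts for this shift.

From the compounds shown here alone, only cyano and nitro have been seen at this place, so it stays open whether the lower number extends to a different group there, such as chlorine, an amine or a carboxylic acid. Going by these compounds, whether cyano gives a similar step elsewhere on the same ring also remains open.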